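A tert-butyl swap at compound 3

The source may hold more compounds than are shown below. What is called first, only, known or untested is meant among the compounds shown, and "the series" means these compounds.

Of the compounds shown here, three have been tested in an ADME assay on Vero cells (Chlorocebus sabaeus) for cytotoxicity, read by CellTiter-Glo, with a stated time of 72 h; a lower number here means that less compound is tolerated, a higher number that more compound is tolerated. Compound 1 (`CC(=O)Nc1cc(/C=C\c2ccc([N+](=O)[O-])o2)ns1`) gives > 50 ug/mL, which is a limit of the assay. Compound 2 (`COCCNC(=O)c1ccc2c(c1)[n+]([O-])c(O)c(C#N)[n+]2[O-]`) gives > 16 ug/mL, which is also a limit. For the measured compounds named here, compound 3 (`CC(C)(C)Nc1n[n+]([O-])c2ccccc2[n+]1[O-]`) gives 8 ug/mL, the only value of the three that is a number and not a limit. Compound 4 (`CCCC(C)Nc1n[n+]([O-])c2ccccc2[n+]1[O-]`) has not yet been measured. It carries 1-methylbutyl in place of tert-butyl on a nitrogen on an aromatic ring. Going by the values given here, no measured pair shows this change, so no shift beyond the usual scatter is expected in this assay. The expected step is a 1.3-fold lower number from compound 3 to compound 4 (0.12 log units; within the scatter). For compound 4 the estimated value is 6 ug/mL, with an expected range of 2.5 ug/mL to 16 ug/mL.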

Compound 4, half-maximal cytotoxic concentration: 26 ug/mL
Compound 4: the middle estimate sits 4.3-fold (0.64 log units) below what was measured; the whole stated range lies below it.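

For the compounds shown here, with 1-methylbutyl in place of tert-butyl on a nitrogen on an aromatic ring, this assay moves by a 3.3-fold higher number from compound 3 to compound 4 (0.51 log units; beyond the scatter) and gives this study its only step between compounds that differ in one place. Compounds 1 and 2 could not show this, since neither differs from compound 3 in one place only, and the step marks this alkyl group on the nitrogen as a point where the tolerated concentration changes. Nothing in the data shown accounts for the step. On these data alone, how a straight pentyl chain, a cyclohexyl ring or a chain ending in an amine would read at this nitrogen stays open. As far as these compounds go, whether the same swap gives a similar step on another core also stays open.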